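The source may report more compounds than this note shows. Statements on the series, on what has been measured and on what is new or still open speak of the compounds shown alone.

Working notes on the series. The shared core of compound 1 `COc1ccc(-c2c(-c3ccc(OC)cc3)n(Cc3ccccc3)c3ncn(CCCO)c(=N)c23)cc1` carries a 3-hydroxypropyl group on the ring nitrogen, and in an ADME assay for permeability, using PAMPA, with a stated time of 30 min, at pH 7.4 (on this read-out higher numbers stand for higher permeability and lower numbers for lower permeability), compound 1 reaches only the upper limit of the method, reported as > 1000 10^-6 cm/s. Compound 2 `COc1ccc(-c2c(-c3ccc(OC)cc3)n(Cc3ccccc3)c3ncn([C@H]4CC[C@H](O)CC4)c(=N)c23)cc1` puts a 4-hydroxycyclohexyl group in that place, and in this assay compound 2 gives 196 10^-6 cm/s. Compound 3 `COc1ccc(-c2c(-c3ccc(OC)cc3)n(Cc3ccccc3)c3ncn([C@@H]4CCCC[C@H]4O)c(=N)c23)cc1` carries a 2-hydroxycyclohexyl group there, and in this assay compound 3 is again returned as a limit, > 1000 10^-6 cm/s. Compound 3 therefore stands at the top of the numbers shown, together with the limit value of compound 1, and the step of an at least 5.1-fold higher number from compound 2 to compound 3 (0.70 log units; beyond the scatter) marks it apart from compound 2. The step of an at least 5.1-fold lower number from compound 1 to compound 2 (0.70 log units; beyond the scatter) and the unreadable step that the two limits leave unreadable from compound 1 to compound 3 both involve a limit; that two of the three values sit at the limit of > 1000 10^-6 cm/s in this assay, at which 2 of the 3 values shown sit, is what keeps those steps from being sized.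

Compound 4 `COc1ccc(-c2c(-c3ccc(OC)cc3)n(Cc3ccccc3)c3ncn(CC4CCOC4)c(=N)c23)cc1` changes the same position: (oxolan-3-yl)methyl in place of 2-hydroxycyclohexyl on an aromatic nitrogen. Among the compounds with values here, no measured step carries a group without a hydroxyl at this position, so the step of an at least 5.1-fold higher number from compound 2 to compound 3 (0.70 log units; beyond the scatter) is the only one that speaks to how much the group there can move the number. The expected step is an at least 1.2-fold lower number from compound 3 to compound 4 (0.09 log units; that floor lies within the scatter), meaning compound 4 is expected to stay high. For compound 4 the estimate in this assay is 800 10^-6 cm/s, in the range 250 10^-6 cm/s to 1500 10^-6 cm/s.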

Compound 4, apparent permeability: > 1000 10^-6 cm/s
Compound 4: no number, only a limit; the forecaster's own chance of this, stated with the estimate: 45%; middle value at least 1.2-fold (0.09 log units) from the limit.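

In this assay compound 4 is returned only as a limit, and it is the one compound shown whose group on the aromatic nitrogen carries no hydroxyl: (oxolan-3-yl)methyl has 0 hydrogen-bond donors, where 2-hydroxycyclohexyl has 1. Within the data shown here, the result is an at least 5.1-fold higher number from compound 2 to compound 4 (0.70 log units; beyond the scatter), so a group without a donor now joins 3-hydroxypropyl and 2-hydroxycyclohexyl on the high side of compound 2, and 4-hydroxycyclohexyl remains the only group here that gives a readable number. The steps linking compound 4 to compound 3 and to compound 1 cannot be read, because all three compounds stand at the same limit: the limit of > 1000 10^-6 cm/s in this assay, at which 3 of the 4 values shown sit.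

Any order among compound 1, compound 3 and compound 4 stays open, as does whether (oxolan-3-yl)methyl differs at all from the two hydroxylated groups that share this limit. The compounds shown also leave open how this assay would read with an unsubstituted cyclohexyl, an amine or a carboxylic acid on this nitrogen, which would show whether compound 2 is an isolated case.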